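Aryl urea variants on the shared core: chloro to trifluoromethyl

The source may report more compounds than this note shows. Statements on the series, on what has been measured and on what is new or still open speak of the compounds shown alone.

Measured compounds:
compound 1 `COc1cc(NC(C)CCCNC(=O)NNC(=O)Nc2cccc(F)c2)c2ncccc2c1` gives 9500 nM
compound 2 `COc1cc(NC(C)CCCNC(=O)Nc2ccc(F)cc2)c2ncccc2c1` gives 25000 nM
compound 3 `COc1cc(NC(C)CCCNC(=O)Nc2cccc(Cl)c2)c2ncccc2c1` gives 26000 nM

All three numbers come from a functional assay on SW-620 cells (Homo sapiens) for inhibition, read by MTT assay, with a stated time of 72 h; on this read-out lower numbers stand for stronger inhibition and higher numbers for weaker inhibition. Compound 3 holds the highest of the three numbers; its nearest neighbour is compound 2, and the step of a 1.0-fold higher number from compound 2 to compound 3 (0.02 log units; within the scatter) lies within the scatter, so no order between these two can be claimed. The steps of a 2.6-fold higher number from compound 1 to compound 2 (0.42 log units; beyond the scatter) and a 2.7-fold higher number from compound 1 to compound 3 (0.44 log units; beyond the scatter) are modest and beyond the scatter, so compound 1 sits apart from the other two.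

Compound 4 `COc1cc(NC(C)CCCNC(=O)Nc2cccc(C(F)(F)F)c2)c2ncccc2c1` is not yet measured. Relative to compound 3 the change is trifluoromethyl in place of chloro on an aromatic carbon. Within the data shown here, no measured step exchanges chloro for trifluoromethyl, so the only step that bears on it is the one within the aryl urea series, a 1.0-fold higher number from compound 2 to compound 3 (0.02 log units; within the scatter), which was within the scatter; the larger steps from compound 1 concern a different change in the linker and do not apply. On that basis a step of no more than the scatter is expected in this assay, a 1.2-fold lower number from compound 3 to compound 4 (0.07 log units; within the scatter). Compound 4 is therefore estimated at 22000 nM in this assay, with a range from 9000 nM to 55000 nM.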

Compound 4, half-maximal inhibitory concentration: 22000 nM
Compound 4: the middle estimate sits on the measured number at the digits printed; the measured number falls inside the stated range.
By their numbers in this assay, from the lowest: compound 1; then compounds 4, 2 and 3 (each within the scatter of the next).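

In this assay the position on the aromatic carbon takes a trifluoromethyl of 4 heavy atoms in place of a single chlorine with a step that stays within the scatter (a 1.2-fold lower number from compound 3 to compound 4 (0.07 log units; within the scatter)), so this exchange gives no readable change at this position. The wider aryl exchange reads the same way (a 1.1-fold lower number from compound 2 to compound 4 (0.06 log units; within the scatter)), which leaves compounds 2, 3 and 4 as one unordered group, while the step to the 3-(trifluoromethyl)phenyl urea remains modest but beyond the scatter (a 2.3-fold higher number from compound 1 to compound 4 (0.36 log units; beyond the scatter)) and keeps compound 1 apart from all three. Nothing available explains why these aryl changes leave the number in place or why compound 1 stands apart.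

Open, going by these compounds, is whether a group of another kind on the same aromatic carbon, such as an amine or a carboxylic acid, would produce a step beyond the scatter, given that chloro and trifluoromethyl cannot be separated here. Also open, on these data alone, is whether the difference of compound 1 would carry over to a version bearing 3-(trifluoromethyl)phenyl on its longer carbamoylamino end.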